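Notes on the step from compound 3 to compound 4

This account rests on a few compounds, and the source may have more. Where it says the series, first, only, none or still open, it means among the compounds named here.

Compound 1 `O=C1Nc2ccccc2/C1=C/c1ccc(-c2cn(-c3cccc(Cl)c3)nn2)cc1` gives > 20000 nM in a functional assay on MKN-45 cells (Homo sapiens) for inhibition, read by CCK-8 assay, with a stated time of 24 h (on this read-out lower numbers stand for stronger inhibition and higher numbers for weaker inhibition), which is a limit and not a number. For the measured compounds named here, compound 2 `O=C1Nc2ccccc2/C1=C/c1ccc(-c2cn(-c3ccc(Cl)cc3)nn2)cc1` gives 16200 nM and compound 3 `N#Cc1ccccc1-n1cc(-c2ccc(/C=C3\C(=O)Nc4ccccc43)cc2)nn1` gives 14600 nM in this assay, which places compound 3 level with compound 2, its only numeric neighbour. Compound 4 `O=C1Nc2ccccc2/C1=C/c1ccc(-c2cn(-c3ccc(Cl)c(C(F)(F)F)c3)nn2)cc1` is the next case, with 4-chloro-3-(trifluoromethyl)phenyl in place of 2-cyanophenyl on an aromatic nitrogen as the change: 4-chloro-3-(trifluoromethyl)phenyl in place of 2-cyanophenyl on an aromatic nitrogen. Three measured exchanges at this nitrogen bear on it: an at least 1.2-fold lower number from compound 1 to compound 2 (0.09 log units; that floor lies within the scatter), then an at least 1.3-fold lower number from compound 1 to compound 3 (0.13 log units; that floor lies within the scatter), then a 1.1-fold lower number from compound 2 to compound 3 (0.05 log units; within the scatter). None of them goes beyond the scatter, so no step beyond the scatter is expected in this assay, and the expected step is a 1.2-fold lower number from compound 3 to compound 4 (0.09 log units; within the scatter) here. For compound 4 the estimated value is 12000 nM, with an expected range of 4500 nM to 20000 nM here.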

Compound 4, half-maximal inhibitory concentration: 8890 nM
For compound 4 the middle estimate is 1.3-fold (0.13 log units) above the measured one; low and high end bracket the measured number.
By their numbers in this assay, from the lowest: compounds 4, 3 and 2 (each within the scatter of the next). At a limit, above all of these: compound 1.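

In this assay, trifluoromethyl on the 4-chlorophenyl ring gives no step beyond the scatter (a 1.8-fold lower number from compound 2 to compound 4 (0.26 log units; within the scatter)), and the exchange for 2-cyanophenyl stays within it too (a 1.6-fold lower number from compound 3 to compound 4 (0.22 log units; within the scatter)). For the compounds shown here, only the exchange for 3-chlorophenyl gives the first step beyond the scatter at this nitrogen (an at least 2.2-fold lower number from compound 1 to compound 4 (0.35 log units; beyond the scatter)), and that step is only a floor. Compound 1 carries a limit and not a number, which leaves the full size of that step unread: the limit of > 20000 nM in this assay, at which 1 of the 4 values shown sits. Going by these compounds, whether an amine or a carboxylic acid on this phenyl ring would move the number remains open.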